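The compounds below may be only part of what the source reports. "The series", "measured", "known", "first", "only" and "open" are said of these compounds alone.

Compounds measured in a functional assay on KB cells (Homo sapiens) for cytotoxicity, read by colorimetric assay; a higher number here means a weaker inhibitor, a lower number a stronger inhibitor:
compound 1, `COc1cc([C@@H]2CCc3cc(O)c(OC)cc3O2)ccc1O`: 69000 nM
compound 2, `COc1cc2c(cc1O)CC[C@@H](c1ccc(O)c(O)c1)O2`: 24600 nM
compound 3, `COc1cc(OC)c2c(c1)O[C@H](c1ccc(O)c(O)c1)CC2`: 31800 nM

Compound 2 gives the lowest of the three numbers in this assay, though its gap to compound 3 lies within the scatter; only compound 1 stands clearly apart. Compound 4, `COc1cc2c(cc1OC)O[C@H](c1ccc(O)c(O)c1)CC2`, is not yet measured. It differs from compound 2 by methyl in place of hydrogen on an oxygen on an aromatic ring.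

Within the data shown here, the one measured step of this kind is the reverse exchange, a 2.8-fold lower number from compound 1 to compound 2 (0.45 log units; beyond the scatter). Compound 3, which carries methyl on both such oxygens of its core, sits within the scatter of compound 2, which suggests that this particular exchange may count for little. The account therefore expects for compound 4 a small rise, a 1.4-fold higher number from compound 2 to compound 4 (0.15 log units; within the scatter), and estimates 35000 nM, with a range from 15000 nM to 80000 nM.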

Compound 4, half-maximal inhibitory concentration: 43100 nM
For compound 4 the middle estimate is 1.2-fold (0.09 log units) below the measured one, and the stated range covers the measured number.
By their numbers in this assay, from the lowest: compounds 2, 3, 4 and 1 (each within the scatter of the next, the first and the last beyond it).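

In this assay, capping the hydroxy on the core of compound 2 as methoxy gives a 1.8-fold higher number from compound 2 to compound 4 (0.24 log units; within the scatter), so at this oxygen the exchange cannot be told from the scatter. The earlier step of this kind, a 2.8-fold lower number from compound 1 to compound 2 (0.45 log units; beyond the scatter), lay at a different oxygen and stood beyond the scatter, so the same exchange need not read alike at every such oxygen. No measurement offered here explains this.

The compounds shown leave open whether a longer chain such as propyl, or an amine, on this oxygen would shift the number beyond the scatter.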